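The source may hold more compounds than are shown below. What is called first, only, known or untested is meant among the compounds shown, and "the series" means these compounds.

Compound 1 `CC(C)=CCOc1cc(Nc2nccs2)ccc1Cl` gives 26000 nM in a functional assay on MT2 cells (Homo sapiens) for cytotoxicity, read by MTT assay (a lower number here means that less compound is tolerated, a higher number that more compound is tolerated), the highest of the two numbers recorded there. Its nearest neighbour is compound 2 `Clc1ccc(Nc2nccs2)cc1OCC1CCCCC1`, which gives 15000 nM in this assay, and the step of a 1.7-fold lower number from compound 1 to compound 2 (0.24 log units; within the scatter) lies within the scatter. Compound 3 `CC(C)=CCOc1cc(Nc2ncccn2)ccc1Cl` differs from compound 1 by pyrimidin-2-yl in place of 1,3-thiazol-2-yl on a nitrogen on an aromatic ring. Among the compounds with values here, the only measured step concerns the chain on the oxygen, not the ring on the nitrogen, so nothing recorded bears directly on this change, and no step beyond the scatter is expected. The expected step is no change at the digits printed from compound 1 to compound 3 (within the scatter). For compound 3 the estimated value in this assay is 26000 nM, with a range from 10000 nM to 65000 nM.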

Compound 3, half-maximal cytotoxic concentration: 2500 nM
For compound 3 the middle estimate is 10-fold (1.02 log units) above the measured one; the whole stated range lies above it.
By their numbers in this assay, from the lowest: compound 3; then compounds 2 and 1 (each within the scatter of the next).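

In this assay the group on the nitrogen proves far from indifferent: pyrimidin-2-yl in place of 1,3-thiazol-2-yl gives a 10-fold lower number from compound 1 to compound 3 (1.02 log units; beyond the scatter), whereas the change on the oxygen chain gave only a 1.7-fold lower number from compound 1 to compound 2 (0.24 log units; within the scatter). Less of compound 3 is tolerated, although the two rings carry equal counts of hydrogen-bond donors and acceptors. Nothing available accounts for this step. Going by these compounds, it remains open whether cyclohexyl on the oxygen chain would give a similar number alongside pyrimidin-2-yl. On these data alone, how a pyridin-2-yl or phenyl ring on the nitrogen would compare also remains open.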